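This account rests on a few compounds, and the source may have more. Where it says the series, first, only, none or still open, it means among the compounds named here.

Compound 1, `O=C(Nc1cc(F)cc(F)c1)c1cc(=O)[nH]c2cc(C(F)(F)F)ccc12`: in a functional assay on KYSE-70 cells for antiproliferative activity against KYSE-70 cell line (Homo sapiens), read by MTT assay, with a stated time of 72 h (a higher number here means a weaker inhibitor, a lower number a stronger inhibitor), compound 1 gives 14200 nM.
Compound 2, `COc1ccc2c(C(=O)Nc3cc(F)cc(F)c3)cc(=O)[nH]c2c1`: compound 2 reaches only the limit > 20000 nM in this assay.
Compound 3, `O=C(Nc1cccc(F)c1)c1cc(=O)[nH]c2cc(-c3ccccc3)ccc12`: compound 3 also sits at the limit > 20000 nM in this assay, so no number is known for it.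

Compound 3 therefore stands at the weak end of what this assay reports, with no value inside the measured window. Compound 4, `O=C(Nc1cccc(F)c1)c1cc(=O)[nH]c2cc(-c3ccc(F)nc3)ccc12`, differs from compound 3 by 6-fluoropyridin-3-yl in place of phenyl on an aromatic carbon.

Going by the values given here, the only measured step, an at least 1.4-fold higher number from compound 1 to compound 2 (0.14 log units; that floor lies within the scatter), concerns a different position and a different pair of groups, so it does not bear on the present change; nothing among the measured compounds tests a change at this position. What the three values share is the limit of > 20000 nM in this assay, at which 2 of the 3 values shown sit, and with compound 3 already there, the working expectation for compound 4 is a result at or near that limit, with no step beyond the scatter: a number no higher from compound 3 to compound 4 (the limit leaves the size open). On that basis compound 4 is estimated at 20000 nM, in a range from 6000 nM to 45000 nM.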

Compound 4, half-maximal inhibitory concentration: > 20000 nM
Compound 4: a limit, no number; the forecaster's own chance of this, stated with the estimate: 60%; the middle value sits exactly at the limit.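

In this assay compound 4 gives > 20000 nM, a limit and not a number. Compound 3 also sits at a limit, so no step can be read between compound 3 and compound 4. The compounds shown leave open whether any group at this place gives a readable value.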